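Compound 4 Against Its Brominated Cyano Neighbour

The source may report more compounds than this note shows. Statements on the series, on what has been measured and on what is new or still open speak of the compounds shown alone.

compound 1 `CCOc1ccc(/C=N/NC(=O)COc2cccc3ccccc23)cc1O` gives 18.1 ug/mL
compound 2 `C/C(=N\NC(=O)COc1cccc2ccccc12)c1ccc(C#N)cc1Br` gives 12.7 ug/mL
compound 3 `O=C(COc1cccc2ccccc12)N/N=C/c1ccccc1Br` gives 100 ug/mL

These values come from an ADME assay on HEL cells (Homo sapiens) for cytotoxicity; a higher number here means that more compound is tolerated, a lower number that less compound is tolerated. Compound 2 lies within the scatter of compound 1 and well beyond it from compound 3, the furthest of the three. Compound 4 `C/C(=N\NC(=O)COc1cccc2ccccc12)c1ccc([N+](=O)[O-])cc1` has not yet been measured. It has 4-nitrophenyl in place of 2-bromo-4-cyanophenyl on a carbon with a double bond to nitrogen. Going by the values given here, no two measured compounds differ in one place only, so the data offer no direct guide to this change. In this assay, no change beyond the scatter is expected, with a slight upward lean at most. The estimated move is a 1.7-fold higher number from compound 2 to compound 4 (0.24 log units; within the scatter). For compound 4 the expected value is 22 ug/mL, within an estimated range of 7 ug/mL to 70 ug/mL.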

Compound 4, half-maximal cytotoxic concentration: > 100 ug/mL
Compound 4 gave a limit, no number; the forecaster's own chance of this, stated with the estimate: 10%; middle value at least 4.5-fold (0.65 log units) from the limit.
By their numbers in this assay, from the lowest: compounds 2 and 1 (each within the scatter of the next); then compound 3.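

In this assay, going by these compounds alone, 4-nitrophenyl in place of 2-bromo-4-cyanophenyl on a carbon with a double bond to nitrogen gives an at least 7.8-fold higher number from compound 2 to compound 4 (0.89 log units; beyond the scatter), the first single-place comparison here, showing that this position can move the tolerated concentration beyond the scatter. Compound 4 gives > 100 ug/mL, which is a limit and not a number. The full size of the step therefore stays unknown, because the reading ends at a limit: the limit of > 100 ug/mL in this assay, at which 1 of the 4 values shown sits.

The change removes bromine and nitrile and brings in nitro together, so the compounds shown do not separate their contributions. As far as these compounds go, whether a 4-aminophenyl group at this place would give a similar result remains open.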